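This account rests on a few compounds, and the source may have more. Where it says the series, first, only, none or still open, it means among the compounds named here.

In a functional assay on A549 cells (Homo sapiens) for antiproliferative activity, read by MTT assay, with a stated time of 48 h (on this read-out lower numbers stand for stronger inhibition of growth and higher numbers for weaker inhibition of growth), compound 1 `COC(=O)N1N=C(c2ccc(OC)cc2)CC1c1cc(OC)c(OC)c(OC)c1` gives 3400 nM as its measured value. Compound 2 `COc1ccc(C2=NN(C(=O)OCc3ccccc3)C(c3cc(OC)c(OC)c(OC)c3)C2)cc1` stands at > 10000 nM in this assay as a limit of the assay and not a number. For the measured compounds named here, the one measured step of an at least 2.9-fold higher number from compound 1 to compound 2 (0.46 log units; beyond the scatter) lies at another place in the structure and bears only indirectly on what follows. Compound 3 `COc1cc(C2CC(c3cccc(O)c3)=NN2C(=O)OCc2ccccc2)cc(OC)c1OC` carries 3-hydroxyphenyl in place of 4-methoxyphenyl on a carbon with a double bond to nitrogen and is otherwise unchanged. Going by the values given here, no measured step touches that place, so no step beyond the scatter is expected in this assay and neither direction is favoured. The estimated step of a number no higher from compound 2 to compound 3 (the limit leaves the size open) is correspondingly open. Compound 3 is estimated at 10000 nM with an expected range from 3000 nM to 30000 nM as its upper end.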

Compound 3, concentration for 50% growth inhibition: > 10000 nM
Compound 3 ended at the assay's limit; the forecaster's own chance of this, stated with the estimate: 55%; the middle value sits exactly at the limit.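

Compound 2 and compound 3 both stand at a limit in this assay and not at a number, so no step can be read between them. Going by these compounds, whether 3-hydroxyphenyl in place of 4-methoxyphenyl on a carbon with a double bond to nitrogen alters growth inhibition stays open.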